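The source may report more compounds than this note shows. Statements on the series, on what has been measured and on what is new or still open speak of the compounds shown alone.

Measured compounds:
compound 1, `CCCS(=O)(=O)Nc1ccc(F)c(C(=O)c2n[nH]c3ncc(-c4ccc(N)cc4)cc23)c1F`, gives 3.7% in an assay for binding affinity to dual specificity mitogen-activated protein kinase kinase 4 (Homo sapiens), read by KINOMEscan, tested at 10 nM; a higher number here means a weaker effect of the compound at the concentration tested, a lower number a stronger effect;
compound 2, `CCCS(=O)(=O)Nc1ccc(F)c(C(=O)c2n[nH]c3ncc(-c4ccc(S(N)(=O)=O)cc4)cc23)c1F`, gives 5.1% in this assay;
compound 3, `CCCS(=O)(=O)Nc1ccc(F)c(C(=O)c2n[nH]c3ncc(-c4ccc(C(N)=O)cc4)cc23)c1F`, gives 4% in this assay.

All three numbers sit close together. Compound 2 carries the highest of them, but the gap a number 1.4 percentage points higher from compound 1 to compound 2 (within the scatter) and the gap a number 1.1 percentage points lower from compound 2 to compound 3 (within the scatter) both fall inside the usual scatter, so the three compounds cannot be told apart in this assay. Among the measured compounds shown here, the only other measured comparison, a number 0.3 percentage points higher from compound 1 to compound 3 (within the scatter), is likewise within the scatter. Every change seen so far swaps the group on the pendant aromatic ring without moving the read-out.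

Compound 4, `CCCS(=O)(=O)Nc1ccc(F)c(C(=O)c2n[nH]c3ncc(-c4ccc(S(N)(=O)=O)cc4F)cc23)c1F`, differs from compound 2 by fluoro in place of hydrogen on an aromatic carbon. For the measured compounds named here, no measured step touches a hydrogen on that ring, so the expectation rests on the general quiet of the series: the three swaps already made left this assay unchanged, and a single fluoro is not expected to do otherwise. Compound 4 is therefore expected to show a step of a number 0.1 percentage points lower from compound 2 to compound 4 (within the scatter), within the scatter. Compound 4 is estimated at 5%, with a range from 1% to 12%.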

Compound 4, a percentage reported as activity, at one concentration (the size of the read-out at that concentration, not a potency): 9.4%
For compound 4 the middle estimate is 4.4 percentage points below the measured one, within the range that was stated.
By their numbers in this assay, from the lowest: compounds 1, 3, 2 and 4 (each within the scatter of the next).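

Among the compounds shown here, compound 4 is the first here to alter a hydrogen on the pendant ring itself, placing fluoro ortho to a large group and meta to a sulfamoyl group, and the step of a number 4.3 percentage points higher from compound 2 to compound 4 (within the scatter) shows that this position takes fluoro without a readable change in this assay at the concentration tested. The wider comparisons, a number 5.4 percentage points higher from compound 3 to compound 4 (within the scatter) and a number 5.7 percentage points higher from compound 1 to compound 4 (within the scatter), agree, so the four compounds still cannot be told apart in this assay here. No supporting data bear on this result.

The compounds shown leave open whether a larger group at this same place, such as chloro, methoxy or trifluoromethyl, would leave the read-out equally unchanged. They also leave open how fluoro behaves when a carboxylic acid or a morpholine takes the place of the sulfamoyl group.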